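Chloro to trifluoromethyl on the urea aryl of compound 1

The source may hold more compounds than are shown below. What is called first, only, known or untested is meant among the compounds shown, and "the series" means these compounds.

Measured so far in a functional assay on MDA-MB-435 cells (Homo sapiens) for inhibition, read by sulforhodamine B assay, with a stated time of 48 h; a higher number here means that more compound is tolerated, a lower number that less compound is tolerated:
compound 1, `O=C(Nc1cccc(-n2cc(-c3ccncc3)c(-c3ccc(Cl)c(O)c3)n2)c1)Nc1ccc(Cl)c(Cl)c1`: > 32500 nM
compound 2, `COc1cc(-c2nn(-c3cccc(NC(=O)c4ccc(Cl)c(C(F)(F)F)c4)c3)cc2-c2ccncc2)ccc1Cl`: 24700 nM
compound 3, `O=C(Nc1cccc(-n2cc(-c3ccncc3)c(-c3ccc(Cl)c(O)c3)n2)c1)Nc1cc(C(F)(F)F)cc(C(F)(F)F)c1`: 15600 nM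

Compound 1 reports no number in this assay, only a limit, (the limit of > 32500 nM in this assay, at which 1 of the 3 values shown sits). Compound 3 shares the urea of compound 1 and carries two trifluoromethyl groups on the terminal ring; in this assay compound 3 gives 15600 nM, and compound 2, with an amide in place of the urea, gives 24700 nM; all three sit in the same upper region of this assay.

Compound 4, `O=C(Nc1cccc(-n2cc(-c3ccncc3)c(-c3ccc(Cl)c(O)c3)n2)c1)Nc1ccc(Cl)c(C(F)(F)F)c1`, is made from compound 1 by the change (trifluoromethyl in place of chloro on an aromatic carbon). For the measured compounds named here, no pair of measured compounds isolates this change, so no measured step can be quoted for it. Given that every value shown sits in the same upper region, the step from compound 1 to compound 4 in this assay is expected to be none beyond the usual scatter, an at least 1.3-fold lower number from compound 1 to compound 4 (0.11 log units; that floor lies within the scatter), with a fair chance that compound 4 also returns only a limit. Compound 4 is estimated at 25000 nM, expected between 10000 nM and 60000 nM.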

Compound 4, concentration lethal to 50% of the cells: 21500 nM
Compound 4: the middle estimate sits 1.2-fold (0.07 log units) above what was measured; measured number inside the range.
By their numbers in this assay, from the lowest: compounds 3, 4 and 2 (each within the scatter of the next). At a limit, above all of these: compound 1.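

In this assay, trifluoromethyl in place of chloro on this aromatic carbon, ortho to a chloro group, is now isolated by a pair, as an at least 1.5-fold lower number from compound 1 to compound 4 (0.17 log units; that floor lies within the scatter). The position carries trifluoromethyl with compound 4 at 21500 nM, in the same upper region as the other measured compounds, and the change is not shown to move the number beyond the scatter. The true size of the step cannot be read beyond its floor, as one end of it is a limit: the limit of > 32500 nM in this assay, at which 1 of the 4 values shown sits.

As far as these compounds go, it remains open whether any other group at this position, such as an amine or a carboxylic acid, would bring the number down beyond the scatter. Also open, from the compounds shown here alone, is how the same change reads on an amide, as compound 2 differs from compound 4 in more than one place.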